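Series notes: replacing the ether-linked amine on compound 1

This account rests on a few compounds, and the source may have more. Where it says the series, first, only, none or still open, it means among the compounds named here.

Measured so far in an assay on isolated protein for inhibition of ubiquitin carboxyl-terminal hydrolase 7 (Homo sapiens), read by fluorescence, with stated times of 30 min and 1 h; a lower number here means a stronger inhibitor, a higher number a weaker inhibitor:
compound 1 `Cc1cc(Cl)cc(-c2ccnc3cc(CN4C(=O)CCC4=O)sc23)c1O[C@H]1C[C@H](N)C1`: 3.4 nM
compound 2 `Cc1cc(Cl)cc(-c2ccnc3cc(CN4C(=O)C5CC5C4=O)sc23)c1C[C@@H]1CNC[C@@H](C)O1`: 0.39 nM
compound 3 `Cc1cc(Cl)cc(-c2ccnc3cc(CN4C(=O)C5CC5C4=O)sc23)c1C[C@H]1OCCN[C@@H]1C`: 1.5 nM

Compound 1 gives the highest of the three numbers in this assay, with compound 3 nearest and compound 2 furthest. Going by the values given here, the one single-point step among the measured compounds is a 3.8-fold higher number from compound 2 to compound 3 (0.59 log units; beyond the scatter), a change within the six-membered ring carried on a saturated chain carbon.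

Compound 4 `Cc1cc(Cl)cc(-c2ccnc3cc(CN4C(=O)CCC4=O)sc23)c1CN1[C@@H](C)CNC[C@@H]1C` is not yet measured. The change from compound 1 is (2,6-dimethylpiperazin-1-yl)methyl in place of (3-aminocyclobutyl)oxy on an aromatic carbon. Among the compounds with values here, no measured step bears directly on this exchange: compounds 2 and 3 carry a six-membered ring with hetero atoms on a saturated chain carbon at the same position and give lower numbers than compound 1, but they also differ from compound 1 elsewhere in the core, so that comparison is not a clean one. The step from compound 2 to compound 3 shows only that the substitution pattern within such a ring moves the number modestly.

On that basis, compound 4 is expected to give a somewhat lower number than compound 1, with the step of a 2.3-fold lower number from compound 1 to compound 4 (0.36 log units; beyond the scatter) estimated as modest and uncertain in size. The estimate for compound 4 is 1.5 nM, with a range from 0.4 nM to 6 nM.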

Compound 4, half-maximal inhibitory concentration: 0.32 nM
The estimate for compound 4 lay 4.7-fold (0.67 log units) above the measured number, and the stated range ends above it.
By their numbers in this assay, from the lowest: compounds 4 and 2 (each within the scatter of the next); then compound 3; then compound 1.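

In this assay, going by these compounds alone, the exchange of (3-aminocyclobutyl)oxy for (2,6-dimethylpiperazin-1-yl)methyl on the otherwise unchanged core of compound 1 gives an 11-fold lower number from compound 1 to compound 4 (1.03 log units; beyond the scatter), and this is the first direct reading of a change at this aromatic carbon. The position, ortho to a large group and ortho to a methyl group, accepts the larger group with its six-membered non-aromatic ring, and the step is large although the counts of hydrogen-bond donors and acceptors are the same for the two groups, so those counts do not separate them. No measurement here explains the size of this step.

The compounds shown leave open which part of the entering group carries the step: the carbon link, the piperazine ring or its two methyl groups, a question that an unsubstituted piperazin-1-ylmethyl group or a morpholin-4-ylmethyl group at this position would address. They also leave open whether the (2,6-dimethylpiperazin-1-yl)methyl group behaves in the same way on the core of compound 2, where the ring attached to the core's methyl group differs from that of compound 4.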